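The source may hold more compounds than are shown below. What is called first, only, known or untested is meant among the compounds shown, and "the series" means these compounds.

Measured compounds:
compound 1 `Cn1c(Cc2cccc(C#N)c2)nc2cc(O[C@H]3CC[C@@H](C(=O)O)CC3)ccc21` gives 22000 nM
compound 2 `Cc1cccc(C(=O)c2nc3cc(O[C@H]4CC[C@@H](C(=O)O)CC4)ccc3n2C)c1` gives "not determined" (no result reported)
compound 3 `Cc1cccc(COc2nc3cc(O[C@H]4CC[C@@H](C(=O)O)CC4)ccc3n2C)c1` is still to be measured

In an assay on isolated protein for inhibition of Long-chain-fatty-acid--CoA ligase 1 (Mus musculus), read by mass spectrometry, with a stated time of 90 min, in the presence of a further agent that is not named here (on this read-out higher numbers stand for weaker inhibition and lower numbers for stronger inhibition), compound 1 gives 22000 nM, a weak inhibition. Compound 2 was run in the same assay but gives "not determined" (no result reported), so it stands nowhere on the scale shown; there is no value to set it against compound 1.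

Compound 3 differs from compound 2 in one place: (3-methylbenzyl)oxy in place of (3-methylphenyl)carbonyl on an aromatic carbon. Going by the values given here, with no result for compound 2 and no pair of measured compounds differing in one place, there is nothing to tell the size or direction of this step in this assay. The only anchor is the weak value of compound 1, which shares the core and the acid-bearing ring.

Compound 3 is therefore expected to land near 15000 nM, within a wide range from 2000 nM to 100000 nM.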

Compound 3, half-maximal inhibitory concentration: 8100 nM
Compound 3: middle estimate off by 1.9-fold (0.27 log units), on the high side; measured number inside the range.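

In this assay, going by these compounds alone, placing (3-methylbenzyl)oxy in place of 3-cyanobenzyl gives a 2.7-fold lower number from compound 1 to compound 3 (0.43 log units; beyond the scatter), a modest step but the first sign that the group on this aromatic carbon can shift the read-out. The swap alters both the link to the benzene ring and the group carried on that ring, so this one step cannot show which of the two changes matters. Nothing shown here explains the shift.

The step between compound 2 and compound 3 cannot be read, so the carbonyl link cannot be compared with the oxygen link. Also open, going by these compounds, is how an amine as the link, or a longer chain between the shared core and the benzene ring, would move the number.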